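Lengthening the Amide Chain on a Dimethoxy Core

The source may hold more compounds than are shown below. What is called first, only, known or untested is meant among the compounds shown, and "the series" means these compounds.

Among the two numbers measured so far, compound 2 `CCNC(=O)CC1CCc2cc(OC)c(OC)cc21` gives 23.6% in a functional assay on the whole organism (strain Swiss albino) for inhibition, with Mus musculus as the target, in the writhing test, with stated times of 60 min and 15 min, at a dose of 100 mg/kg by the oral route (a lower number here means less inhibition, a higher number more inhibition at the dose given (going by the name of the read-out)), while compound 1 `COc1cc2c(cc1OC)C(CC(=O)N(C)C)CC2` gives 22.6% in this assay, and the two lie within the scatter of each other. Among the compounds with values here, the single step measured, a number 1 percentage points higher from compound 1 to compound 2 (within the scatter), exchanged one substituent on the amide nitrogen for another without moving the read-out beyond the scatter. Compound 3 `CCCCNC(=O)CC1CCc2cc(OC)c(OC)cc21` differs from compound 2 by ethyl in place of hydrogen on a saturated chain carbon, two bonds along the chain from an amide-type nitrogen. Within the data shown here, no measured step lengthens the chain on the amide nitrogen in this way; the nearest comparison is the step from compound 1 to compound 2, which concerned the same nitrogen and stayed within the scatter. On that basis no step beyond the scatter is expected in this assay, and the estimated step is a number 0.4 percentage points higher from compound 2 to compound 3 (within the scatter). Compound 3 is therefore expected to give about 24%, with a range from 13% to 35%.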

Compound 3, a percentage reported as inhibition, in the whole organism at one dose (the size of the read-out at that dose, not a potency): 39.4%
The estimate for compound 3 lay 15.4 percentage points below the measured number; measured number outside the range, above it.
By their numbers in this assay, from the lowest: compounds 1 and 2 (each within the scatter of the next); then compound 3.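

In this assay, ethyl in place of hydrogen on a saturated chain carbon, two bonds along the chain from an amide-type nitrogen, gives a number 15.8 percentage points higher from compound 2 to compound 3 (beyond the scatter), so this position of the chain can move the read-out beyond the scatter. Butylamino in place of dimethylamino on the carbonyl carbon likewise gives a number 16.8 percentage points higher from compound 1 to compound 3 (beyond the scatter), whereas ethylamino in that place gave only a number 1 percentage points higher from compound 1 to compound 2 (within the scatter). Nothing at hand bears on what lies behind the step from ethylamino to butylamino.

The compounds shown leave open whether a longer chain, such as hexyl on the amide nitrogen, would raise the number again or lower it. They also leave open whether a chain ending in an amine or a carboxylic acid would keep the step seen with butylamino.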